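Azetidine Gives Way to a Fluoroanilino Group

The compounds below may be only part of what the source reports. "The series", "measured", "known", "first", "only" and "open" are said of these compounds alone.

In a functional assay on MCF7 cells (Homo sapiens) for inhibition, read by sulforhodamine B assay (on this read-out higher numbers stand for weaker inhibition and lower numbers for stronger inhibition), compound 1 `Cc1ccc(NC2=CC(=O)c3c(nc4n3[C@H]3OC[C@@H](O)[C@H]3OC4)C2=O)cc1C` gives 4950 nM. Compound 2 `O=C1C(NCc2ccccc2)=CC(=O)c2c1nc1n2[C@H]2OC[C@@H](O)[C@H]2OC1` reaches only a limit of this assay, > 8000 nM. Compound 3 `O=C1C(N2CCC2)=CC(=O)c2c1nc1n2[C@H]2OC[C@@H](O)[C@H]2OC1` likewise reaches only a limit of this assay, > 16000 nM, so its standing is a limit and not a number. Compound 4 `O=C1C(Nc2cccc(F)c2)=CC(=O)c2c1nc1n2[C@H]2OC[C@@H](O)[C@H]2OC1` differs from compound 3 in one place: (3-fluorophenyl)amino in place of azetidin-1-yl on a double-bonded ring carbon. Within the data shown here, the measured step that bears on this runs the other way and was an at least 3.2-fold higher number from compound 1 to compound 3 (0.50 log units; beyond the scatter); the one between compound 2 and compound 3 is a step that the two limits leave unreadable from compound 2 to compound 3. Since the change restores an amine bearing an aromatic ring, as in compound 1, one expects an at least 2.6-fold lower number from compound 3 to compound 4 (0.42 log units; beyond the scatter). Compound 4 is therefore estimated at 6000 nM, between 2000 nM and 20000 nM.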

Compound 4, half-maximal inhibitory concentration: > 4000 nM
Compound 4 was reported as a limit (the forecaster's own chance of this, stated with the estimate: 30%); the middle value is on the limit's open side.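

Compound 4 is reported only as a limit, so its steps from compound 1, compound 2 and compound 3 cannot be read. The compounds shown leave open whether (3-fluorophenyl)amino gives a lower or higher number than the (3,4-dimethylphenyl)amino of compound 1.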